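Oxazole in place of pyrrole on a salicylic acid core

The source may report more compounds than this note shows. Statements on the series, on what has been measured and on what is new or still open speak of the compounds shown alone.

Measured compounds:
compound 1 `O=C(O)c1cc(-n2cccc2)ccc1O`: 50 mg/kg
compound 2 `O=C(O)c1cc(-c2ncc[nH]2)ccc1O`: 200 mg/kg
compound 3 `O=C(O)c1cc(-c2cccs2)ccc1O`: 60 mg/kg

All three share one core and differ only in the five-membered ring attached to it. Their activity was measured in a functional assay on the whole organism for inhibition, with Rattus norvegicus as the target, read by paw edema; on this read-out lower numbers stand for an effect already at smaller amounts and higher numbers for an effect only at larger amounts of compound. Among them compound 1 gives the lowest number; compound 3 is nearest, with a step of a 1.2-fold higher number from compound 1 to compound 3 (0.08 log units; within the scatter), which is within the scatter, and compound 2 is furthest, with a step of a 4.0-fold higher number from compound 1 to compound 2 (0.60 log units; beyond the scatter), a modest shift beyond the scatter.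

Compound 4 `O=C(O)c1cc(-c2ccno2)ccc1O` has not yet been measured. It differs from compound 1 in one place: 1,2-oxazol-5-yl in place of 1H-pyrrol-1-yl on an aromatic carbon.

For the measured compounds named here, two measured steps bear on this change. The step of a 1.2-fold higher number from compound 1 to compound 3 (0.08 log units; within the scatter) shows that exchanging the ring of compound 1 for another five-membered aromatic ring without a hydrogen-bond donor left the number essentially unchanged. The step of a 4.0-fold higher number from compound 1 to compound 2 (0.60 log units; beyond the scatter) shows that a ring carrying a hydrogen-bond donor raised the number modestly. The ring entering in compound 4 has no donor and two acceptors, so the expected step is roughly a 1.4-fold higher number from compound 1 to compound 4 (0.15 log units; within the scatter). Compound 4 is therefore estimated at 70 mg/kg, with a likely range of 30 mg/kg to 160 mg/kg.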

Compound 4, dose for half-maximal effect: 110 mg/kg
Compound 4: the middle estimate sits 1.6-fold (0.20 log units) below what was measured, within the range that was stated.
By their numbers in this assay, from the lowest: compounds 1, 3, 4 and 2 (each within the scatter of the next, the first and the last beyond it).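

In this assay, replacing 1H-pyrrol-1-yl with 1,2-oxazol-5-yl, para to the hydroxy group and meta to the carboxy group, gives a 2.2-fold higher number from compound 1 to compound 4 (0.34 log units; beyond the scatter), so having 0 hydrogen-bond donors on the ring is not enough to keep the number level with compound 1. Compound 4 also cannot be separated from either of the other two rings, with a 1.8-fold higher number from compound 3 to compound 4 (0.26 log units; within the scatter) and a 1.8-fold lower number from compound 2 to compound 4 (0.26 log units; within the scatter), even though those two are themselves set apart by a 3.3-fold lower number from compound 2 to compound 3 (0.52 log units; beyond the scatter); it therefore fills the gap between them and blurs the earlier split into two groups. No measurement of any property of these rings is available to explain the shift.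

The compounds shown leave open how the number would respond at this place to a six-membered ring such as phenyl, or to a five-membered ring carrying a methyl group or an amine. Also open, from the compounds shown here alone, is whether 1,2-oxazol-3-yl, the same ring joined through a different atom, would behave like 1,2-oxazol-5-yl.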